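The source may hold more compounds than are shown below. What is called first, only, known or untested is meant among the compounds shown, and "the series" means these compounds.

Compound 1 `C#Cc1cccc(Nc2ncnc3ccccc23)c1`: 4160 nM
Compound 2 `O=[N+]([O-])c1ccccc1-n1cc(-c2cccc(Nc3ncnc4ccccc34)c2)nn1`: 4760 nM

Both compounds were tested in a functional assay on SK-LU-1 cells (Homo sapiens) for cytotoxicity, read by MTT assay, with a stated time of 3 days; on this read-out higher numbers stand for weaker inhibition and lower numbers for stronger inhibition. Compound 1 gives 4160 nM and compound 2 gives 4760 nM; the two numbers fall within the usual scatter of each other, so nothing separates them. Compound 3 `O=[N+]([O-])c1cccc(-n2cc(-c3cccc(Nc4ncnc5ccccc45)c3)nn2)c1` is not yet measured. It differs from compound 2 in one place: 3-nitrophenyl in place of 2-nitrophenyl on an aromatic nitrogen. Within the data shown here, no measured pair shows what such a move of the nitro group does, so no step beyond the scatter is expected in this assay in either direction; compound 3 is estimated at 4500 nM, within 1800 nM to 11000 nM. The expected change from compound 2 to compound 3 is a 1.1-fold lower number from compound 2 to compound 3 (0.02 log units; within the scatter).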

Compound 3, half-maximal inhibitory concentration: 260000 nM
Compound 3: the middle estimate sits 58-fold (1.76 log units) below what was measured; the whole stated range lies below it.
By their numbers in this assay, from the lowest: compounds 1 and 2 (each within the scatter of the next); then compound 3.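

In this assay the same atoms joined differently give a 55-fold higher number from compound 2 to compound 3 (1.74 log units; beyond the scatter) with only the nitro group moved on the phenyl ring. Among these compounds, on this aromatic nitrogen, then, 2-nitrophenyl and 3-nitrophenyl are far from interchangeable, something the earlier compounds, within the scatter of each other, could not reveal. Nothing available explains this large step.

From the compounds shown here alone, whether a plain phenyl, or an amine in place of the nitro group, would sit closer to compound 2 or to compound 3 remains open.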